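Replacing Fluoro with Acetamido in Compound 1

The source may report more compounds than this note shows. Statements on the series, on what has been measured and on what is new or still open speak of the compounds shown alone.

Within the data shown here, in a functional assay on HepG2 cells (Homo sapiens) for cytotoxicity, read by MTT assay, with a stated time of 24 h (on this read-out lower numbers stand for stronger inhibition and higher numbers for weaker inhibition), compound 1 (`COc1cc(/C=C2\CN(S(=O)(=O)c3ccc(F)cc3)C/C(=C\c3cc(OC)c(OC)c(OC)c3)C2=O)cc(OC)c1OC`) gives 4200 nM and stands level with the only other measured compound. That second compound, compound 2 (`CC(=O)Nc1ccc(S(=O)(=O)N2C/C(=C\c3ccc(C#N)cc3)C(=O)/C(=C/c3ccc(C#N)cc3)C2)cc1`), gives 4880 nM and the two values lie within the usual scatter of each other.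

Compound 3 (`COc1cc(/C=C2\CN(S(=O)(=O)c3ccc(NC(C)=O)cc3)C/C(=C\c3cc(OC)c(OC)c(OC)c3)C2=O)cc(OC)c1OC`) differs from compound 1 in a single place. It carries acetamido in place of fluoro on an aromatic carbon, para to a large group (acetamido in place of fluoro on an aromatic carbon) and the rest of the structure is unchanged. Among the measured compounds shown here, no measured pair differs by this change alone, so its size has not been observed directly.

For the measured compounds named here, the only indirect evidence comes from compound 2, which also carries an acetamido group. Compound 2 at 4880 nM does not stand apart from compound 1, so no step beyond the scatter is expected in this assay in either direction. The expected change is a step of a 1.1-fold higher number from compound 1 to compound 3 (0.03 log units; within the scatter) that remains inside the scatter. For compound 3 the estimated value is 4500 nM with an expected range from 1800 nM to 11000 nM across repeated measurements.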

Compound 3, half-maximal inhibitory concentration: 3890 nM
For compound 3 the middle estimate is 1.2-fold (0.06 log units) above the measured one, and the stated range covers the measured number.
By their numbers in this assay, from the lowest: compounds 3, 1 and 2 (each within the scatter of the next).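

The exchange of 4-fluorophenyl for 4-acetamidophenyl now has a direct reading in this assay: it gives a 1.1-fold lower number from compound 1 to compound 3 (0.03 log units; within the scatter), a step that stays inside the scatter. On the core of compound 1, acetamido, with more heavy atoms than fluoro and with a hydrogen-bond donor and acceptor that fluoro lacks, therefore leaves this read-out without a measurable shift. Compound 2 could not show this, since it differs from compound 1 in more than one place, and nothing available offers an explanation for the result.

What the compounds shown leave open is whether this position stays as unresponsive with other groups on the aromatic carbon, such as an amine, a carboxylic acid or a longer chain in place of the acetyl of acetamido. As far as these compounds go, it is also open whether the same exchange of fluoro and acetamido would read alike on the core of compound 2, which carries nitrile groups, as a single pair on one core cannot settle that.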